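A few compounds are considered here, and "the series" means these few. Any claim that something is new, unique, unknown or untested is made for them only; others in the source may bear on it.

Among the measured compounds shown here, compound 1, `O=C1NC(=O)c2c1c1c3ccc(C(F)(F)F)cc3[nH]c1c1c2c2cccc3c2n1CC(CO)C3`, is one of three compounds measured in a functional assay on NCI-H460 cells (Homo sapiens) for antiproliferative activity (on this read-out higher numbers stand for weaker inhibition and lower numbers for stronger inhibition), where compound 1 gives 690 nM. Compound 2, `O=C1NC(=O)c2c1c1c3ccc(F)cc3[nH]c1c1c2c2cccc3c2n1C(CO)CC3`, gives 260 nM in this assay, and compound 3, `O=C1NC(=O)c2c1c1c3ccccc3ccc1c1c2c2cccc3c2n1CC(CO)C3`, gives 740 nM. Among these numbers compound 1 has the second highest; its value and that of compound 3 lie within the scatter of each other, while the value of compound 2 stands lower by more than the scatter. For the measured compounds named here, no pair of measured compounds differs in only one place, so no single step is available for comparison.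

Compound 4, `O=C1NC(=O)c2c1c1c3ccc(Br)cc3[nH]c1c1c2c2cccc3c2n1CC(CO)C3`, has not been measured. It differs from compound 1 as follows: bromo in place of trifluoromethyl on an aromatic carbon. Going by the values given here, because the value of compound 1 in this assay is 690 nM and no measured step informs this exchange, he expects no step beyond the scatter, a 1.3-fold lower number from compound 1 to compound 4 (0.10 log units; within the scatter). Compound 4 is therefore estimated at 550 nM, with a range from 200 nM to 1500 nM.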

Compound 4, half-maximal inhibitory concentration: 360 nM
Compound 4: middle estimate off by 1.5-fold (0.18 log units), on the high side, and the stated range covers the measured number.
By their numbers in this assay, from the lowest: compounds 2, 4, 1 and 3 (each within the scatter of the next, the first and the last beyond it).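

Among the compounds shown here, compound 1 and compound 4 are the first pair here that differs in one place, so this aromatic carbon can now be read directly: bromo in place of trifluoromethyl gives a 1.9-fold lower number from compound 1 to compound 4 (0.28 log units; within the scatter) in this assay as the only step available. Four heavy atoms leave and one enters, yet the read-out does not separate the two groups at this position, and neither group can be ranked over the other. Nothing measured here speaks to the reason for the size of this step.

The compounds shown leave open whether an amine, a carboxylic acid or a longer chain on this carbon would move the number beyond the scatter. Going by these compounds, compound 2 carries fluoro but differs from compound 1 in more than one place, so how fluoro compares with these two groups also stays open.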